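From a pyrazole to a pyridine on a shared core

The source may report more compounds than this note shows. Statements on the series, on what has been measured and on what is new or still open speak of the compounds shown alone.

Compound 1 `CC(C)Cn1cc(-c2cc(Nc3ccc(OC(F)(F)F)cc3)ncn2)cn1`: > 10000 nM in an ADME assay on BaF3 cells (Mus musculus) for cytotoxicity (a lower number here means that less compound is needed, a higher number that more compound is needed for the effect), a limit of the assay rather than a number.
Compound 2 `CCCn1cc2c(Nc3ccc(OC(F)(F)F)cc3)ncnc2n1`: > 10000 nM in this assay, again a limit of the assay.
Compound 3 `COC(=O)c1cc2c(Nc3ccc(OC(F)(F)F)cc3)ncnc2s1`: > 10000 nM in this assay, again a limit of the assay.

Compound 1 thus stands nowhere in particular among the three: each of them gives only a limit in this assay, and the three limits are the same, so no order among them can be drawn. This is described by the limit of > 10000 nM in this assay, at which 3 of the 3 values shown sit. No two of the measured compounds differ in a single place, so no measured step is available, and no cause for the shared outcome can be given.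

The new compound 4 `FC(F)(F)Oc1ccc(Nc2cc(-c3ccncc3)ncn2)cc1` differs from compound 1 in one place: pyridin-4-yl in place of 1-isobutyl-1H-pyrazol-4-yl on an aromatic carbon. With all three measured compounds sitting at the same limit, there is no evidence that a change of this kind moves the read-out in either direction. Compound 4 is therefore expected to end up near or beyond the same limit in this assay, with an estimated value of 15000 nM in the range 5000 nM to 50000 nM. This estimate means an expected step that the limit leaves unreadable from compound 1 to compound 4, no step beyond the scatter.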

Compound 4, half-maximal effective concentration: > 10000 nM
Compound 4: only a limit was reported (the forecaster's own chance of this, stated with the estimate: 80%); the middle value does not contradict the limit.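

Compound 4, like compound 1, gives only a limit of the assay in this assay, so no step can be read between them for pyridin-4-yl in place of 1-isobutyl-1H-pyrazol-4-yl. The compounds shown leave open at what concentration any of them would reach its half-maximal effect, because all of them share one limit: the limit of > 10000 nM in this assay, at which 4 of the 4 values shown sit.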